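Chain extension on the enamide of compound 3

The source may report more compounds than this note shows. Statements on the series, on what has been measured and on what is new or still open speak of the compounds shown alone.

Three compounds have numbers in a functional assay on HeLa cells (Homo sapiens) for inhibition, read by MTT assay, with a stated time of 72 h; on this read-out higher numbers stand for weaker inhibition and lower numbers for stronger inhibition:

compound 1 `C/C=C/C(=O)Nc1cccc(Oc2nc(Nc3cccc(OC)c3)nc3ccsc23)c1`: 20100 nM
compound 2 `COc1ccc(Nc2nc(Oc3cccc(NC(=O)/C=C/C(C)C)c3)c3sccc3n2)cn1`: > 50000 nM, a limit of the assay
compound 3 `C/C=C/C(=O)Nc1cccc(Oc2nc(Nc3cccc(C#N)c3)nc3ccsc23)c1`: 23600 nM

In this assay, among the compounds with values here, compound 3 holds the highest of the two numbers, with compound 1 the nearest; the only measured single-site step, a 1.2-fold higher number from compound 1 to compound 3 (0.07 log units; within the scatter), lies within the scatter. Within the data shown here, for compound 2 the assay reports only a limit, (the limit of > 50000 nM in this assay, at which 1 of the 3 values shown sits), and compound 2 differs from the others in more than one place, so it supports no step.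

Compound 4 `CCC/C=C/C(=O)Nc1cccc(Oc2nc(Nc3cccc(C#N)c3)nc3ccsc23)c1` differs from compound 3 by ethyl in place of hydrogen on a saturated chain carbon bound to a double-bonded chain carbon. Among the measured compounds shown here, no measured step touches the chain bound to the carbonyl; the one measured step concerns a substituent on the aromatic ring and was within the scatter. For the measured compounds named here, with nothing among the measured compounds pointing to a gain, the expected step is a 1.3-fold higher number from compound 3 to compound 4 (0.10 log units; within the scatter), that is, no change beyond the scatter. Compound 4 is therefore estimated at 30000 nM in this assay, within a range of 12000 nM to 75000 nM.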

Compound 4, half-maximal inhibitory concentration: 42100 nM
Compound 4: the middle estimate sits 1.4-fold (0.15 log units) below what was measured; the measured number falls inside the stated range.
By their numbers in this assay, from the lowest: compounds 1, 3 and 4 (each within the scatter of the next, the first and the last beyond it). At a limit, above all of these: compound 2.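

In this assay, the chain bound to the carbonyl now has its first measured step: a 1.8-fold higher number from compound 3 to compound 4 (0.25 log units; within the scatter). Within the data shown here, the change from prop-1-en-1-yl to pent-1-en-1-yl therefore cannot be told apart from the scatter of repeated measurements, so a first change on this chain, like the earlier one on the aromatic ring, a 1.2-fold higher number from compound 1 to compound 3 (0.07 log units; within the scatter), stays within it. At this place, ethyl in place of hydrogen brings no gain in this assay.

As far as these compounds go, compound 2 remains a limit of the assay and differs from the others in more than one place, so it gives no readable step on this chain: the limit of > 50000 nM in this assay, at which 1 of the 4 values shown sits. Whether a longer chain or an amine at the end of this chain would move the number beyond the scatter stays open.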